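Adding a Methoxy Group to Compound 2

The source may hold more compounds than are shown below. What is called first, only, known or untested is meant among the compounds shown, and "the series" means these compounds.

Measured so far:
compound 1, `COc1cc(-c2cc(/C=C/C(=O)c3ccc(Cl)c(Cl)c3)[nH]n2)cc(OC)c1OC`: 97%
compound 2, `COc1ccc(C(=O)/C=C/c2cc(-c3cc(OC)c(OC)c(OC)c3)n[nH]2)cc1OC`: 98%

In a functional assay on IGROV-1 cells (Homo sapiens) for cytotoxicity, read by sulforhodamine B assay, with a stated time of 48 h, tested at 0.01 uM (on this read-out higher numbers stand for a weaker effect at the one concentration tested and lower numbers for a stronger effect), compound 2 gives 98%, the higher of the two numbers, while compound 1 gives 97%. Going by the values given here, the only measured step, a number 1 percentage points higher from compound 1 to compound 2 (within the scatter), exchanged the ring on the carbonyl carbon and stayed within the scatter, so both compounds show only a weak effect at the concentration tested.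

Compound 3, `COc1cc(C(=O)/C=C/c2cc(-c3cc(OC)c(OC)c(OC)c3)n[nH]2)cc(OC)c1OC`, differs from compound 2 in one place: methoxy in place of hydrogen on an aromatic carbon. Among the compounds with values here, no measured step touches this part of the molecule, so the step from compound 1 to compound 2 bears on it only indirectly, by showing that a change elsewhere left the read-out essentially unchanged. Both measured numbers sit close to the top of the scale, which leaves little room for a higher number. A step beyond the scatter is therefore not expected, and the expected step of a number 2 percentage points lower from compound 2 to compound 3 (within the scatter) lies within it. Compound 3 is expected to give 96%, with a range from 86% to 100%.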

Compound 3, a percentage reported as activity, at one concentration (the size of the read-out at that concentration, not a potency): 104%
For compound 3 the middle estimate is 8 percentage points below the measured one, outside the stated range (above it).
By their numbers in this assay, from the lowest: compounds 1, 2 and 3 (each within the scatter of the next).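

In this assay, methoxy in place of hydrogen gives a number 6 percentage points higher from compound 2 to compound 3 (within the scatter), so this aromatic carbon, ortho to a methoxy group and meta to a large group, can carry the added methoxy without any change beyond the usual scatter. The step from compound 1 to compound 2 exchanged the groups on the ring at the carbonyl carbon, whereas this step adds a single small group to that ring, and it too brings no stronger effect at the one concentration tested, with compound 3 at 104%. Nothing measured here speaks to why the read-out stays where it does.

From the compounds shown here alone, what an amine or a carboxylic acid on this same aromatic carbon would do to the read-out remains open, as does whether a longer chain such as butoxy would give the same picture as methoxy. All three compounds sit near the weak end of the scale at a single concentration, so any differences between them that would appear only at other concentrations cannot be seen from these numbers.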